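Nitro substitution on the phenyl of compound 3

The source may report more compounds than this note shows. Statements on the series, on what has been measured and on what is new or still open speak of the compounds shown alone.

Working notes on the series. Compound 1 `COc1cc2c(Oc3ccc(NC(=O)c4nn(-c5ccccc5)c(=O)c5ccccc45)cc3F)ccnc2cc1OCCCN1CCCC1` gives 480 nM in a functional assay on NCI-H460 cells (Homo sapiens) for cytotoxicity, read by MTT assay, with a stated time of 72 h; on this read-out lower numbers stand for stronger inhibition and higher numbers for weaker inhibition. Compound 2 `COc1ccc(-n2nc(C(=O)Nc3ccc(Oc4ccnc5cc(OCCCN6CCCC6)c(OC)cc45)c(F)c3)c3ccccc3c2=O)cc1` gives 1650 nM in this assay, and compound 3 `COc1cc2c(Oc3ccc(NC(=O)c4nn(-c5ccccc5)c(=O)c5ccccc45)cc3F)ccnc2cc1OCCCN1CCN(C)CC1` gives 450 nM in this assay. Compound 3 thus stands lowest of the three numbers, but its gap to compound 1 lies within the scatter; only its gap to compound 2 lies beyond it.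

Compound 4 `COc1cc2c(Oc3ccc(NC(=O)c4nn(-c5ccc([N+](=O)[O-])cc5)c(=O)c5ccccc45)cc3F)ccnc2cc1OCCCN1CCN(C)CC1` has not yet been measured. It differs from compound 3 by nitro in place of hydrogen on an aromatic carbon, so the phenyl attached to the shared core becomes 4-nitrophenyl. For the measured compounds named here, the one measured step that bears on this is the addition of a group on that same phenyl, a 3.4-fold higher number from compound 1 to compound 2 (0.54 log units; beyond the scatter), which moved the number up. The other step, a 1.1-fold lower number from compound 1 to compound 3 (0.03 log units; within the scatter), concerns the chain end and says nothing about the phenyl. A single precedent is thin ground, and the nitro group is not the methoxy group, so the expectation is held loosely: for compound 4 a modest rise in this assay is expected, roughly a 2.4-fold higher number from compound 3 to compound 4 (0.39 log units; beyond the scatter).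

Compound 4 is estimated at 1100 nM in this assay, with a range from 350 nM to 3500 nM.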

Compound 4, half-maximal inhibitory concentration: 980 nM
Beside the measured number, compound 4's estimate is 1.1-fold (0.05 log units) above it; the range from low to high includes it.
By their numbers in this assay, from the lowest: compounds 3 and 1 (each within the scatter of the next); then compounds 4 and 2 (each within the scatter of the next).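

In this assay, nitro in place of hydrogen on the phenyl, para to a large group, gives a 2.2-fold higher number from compound 3 to compound 4 (0.34 log units; beyond the scatter), so a rise at this position now appears with the 4-methylpiperazin-1-yl chain end as well. Alongside a 3.4-fold higher number from compound 1 to compound 2 (0.54 log units; beyond the scatter), which carries methoxy on the same phenyl with the pyrrolidin-1-yl chain end, this makes two substitutions on the phenyl that move the number up beyond the scatter, and no compound shown goes against this, though two steps are a narrow base for a pattern. Nothing available accounts for either rise, and no measurement outside this cytotoxicity read-out bears on the result.

The compounds shown leave open whether the rise holds for other groups on this phenyl, such as an amine, a carboxylic acid or a chlorine atom, and whether any group there brings the number down. They also leave open how methoxy and nitro compare on a single chain end, since the two steps start from different parent compounds and differ in both the entering group and the chain end.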